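The source may hold more compounds than are shown below. What is called first, only, known or untested is meant among the compounds shown, and "the series" means these compounds.

Within the data shown here, in an ADME assay on THP-1 cells (Homo sapiens) for cytotoxicity, read by flow cytometry and propidium iodide staining, with a stated time of 72 h (a lower number here means a stronger inhibitor, a higher number a weaker inhibitor), three related compounds have numbers so far. Compound 1 (`COc1cccc(-c2oc3ccc(N)cc3c(=O)c2O)c1`) gives 2000 nM, compound 2 (`COc1cccc(-c2oc3ccc(NC(C)=O)cc3c(=O)c2OC)c1`) gives 5000 nM, and compound 3 (`COc1c(-c2ccccc2)oc2ccc(N)cc2c1=O`) gives 74000 nM. Compound 3 thus holds the highest of the three numbers, which makes it the weakest inhibitor of the set, and its distance from each of the other two lies beyond the usual scatter.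

Compound 4 (`COc1cccc(-c2oc3ccc(N)cc3c(=O)c2OC)c1`) is compound 3 with a single change: methoxy in place of hydrogen on an aromatic carbon. This places methoxy in place of hydrogen on an aromatic carbon, meta to a large group. Among the measured compounds shown here, no pair of measured compounds shows this change alone, as compound 1 and compound 2 each differ from compound 3 in more than one place. Even so, both carry this methoxy, and compound 1 at 2000 nM and compound 2 at 5000 nM both sit far lower than compound 3. A drop beyond the scatter is therefore expected, estimated as a 12-fold lower number from compound 3 to compound 4 (1.09 log units; beyond the scatter). For compound 4, the expected value is 6000 nM, with an estimated range of 1500 nM to 25000 nM.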

Compound 4, half-maximal inhibitory concentration: 37000 nM
Compound 4: the middle estimate sits 6.2-fold (0.79 log units) below what was measured; the whole stated range lies below it.
By their numbers in this assay, from the lowest: compound 1; then compound 2; then compounds 4 and 3 (each within the scatter of the next).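

In this assay, methoxy in place of hydrogen on this aromatic carbon, meta to a large group, does not separate the two compounds on its own: a 2.0-fold lower number from compound 3 to compound 4 (0.30 log units; within the scatter) is a step that stays within the scatter. Changes elsewhere on compound 4 count for far more, as hydrogen in place of acetyl on the nitrogen gives a 7.4-fold higher number from compound 2 to compound 4 (0.87 log units; beyond the scatter), and methyl in place of hydrogen on the oxygen gives a 19-fold higher number from compound 1 to compound 4 (1.27 log units; beyond the scatter), the larger of the two steps. No measurement shown here accounts for these differences.

As far as these compounds go, it remains open whether a different group on this aromatic carbon, such as an amine or a longer chain like ethoxy, would shift the number beyond the scatter. It is also unknown whether this methoxy would matter as little with acetyl on the nitrogen or with hydrogen on the oxygen.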